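Amino for nitro on the trimethoxy chalcone

The source may report more compounds than this note shows. Statements on the series, on what has been measured and on what is new or still open speak of the compounds shown alone.

Compound 3, `COc1cc(C(=O)/C=C/c2ccc([N+](=O)[O-])cc2)cc(OC)c1OC`, carries a nitro group and in a functional assay on B16 cells (Mus musculus) for cytotoxicity, read by MTT assay, with a stated time of 3 days (a lower number here means a stronger inhibitor, a higher number a weaker inhibitor), reaches only a limit of the assay, > 100000 nM. Compound 1, `COc1ccc(C(=O)/C=C/c2ccccc2)cc1N`, likewise gives only a limit in this assay, > 100000 nM. Within the data shown here, compound 2, `COc1cc(/C=C/C(=O)c2ccc(OC)c(N)c2)cc(OC)c1`, is the one compound with a number in this assay, at 8800 nM. Compound 3 therefore stands at the limit of > 100000 nM in this assay, at which 2 of the 3 values shown sit, and offers no number of its own for comparison.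

Compound 4, `COc1cc(C(=O)/C=C/c2ccc(N)cc2)cc(OC)c1OC`, differs from compound 3 by amino in place of nitro on an aromatic carbon. Among the measured compounds shown here, no pair of measured compounds differing in one place exists, so the size of such a change has no precedent in this assay. Compound 2 shows that an amino-bearing member of the series can give a number, 8800 nM. That number is the basis for expecting compound 4 to give a number of its own in this assay. The step from compound 3 to compound 4 is expected to be toward stronger inhibition, an at least 3.3-fold lower number from compound 3 to compound 4 (0.52 log units; beyond the scatter), beyond the scatter but with wide uncertainty. Compound 4 is estimated at 30000 nM, within 5000 nM to 150000 nM.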

Compound 4, half-maximal inhibitory concentration: 30000 nM
Estimate against measurement, compound 4: no gap at the digits printed; the range from low to high includes it.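

Among these compounds, at this position, on an aromatic carbon para to a large group, amino in place of nitro gives the only readable step in this assay: an at least 3.3-fold lower number from compound 3 to compound 4 (0.52 log units; beyond the scatter). Compound 4 therefore shows that a change at this single position can turn a compound at the limit into one with a number of its own. The size of the step remains a bound and not a measured difference, since one end of it is a limit: the limit of > 100000 nM in this assay, at which 2 of the 4 values shown sit.

The compounds shown leave open how a hydroxyl group, a dimethylamino group or an acetamide at this position would compare with amino. On these data alone, whether amino in place of nitro has a similar effect on another core also remains open, as this single pair cannot settle it.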